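Swapping benzoyl for pyridin-4-yl on a shared core

The source may hold more compounds than are shown below. What is called first, only, known or untested is meant among the compounds shown, and "the series" means these compounds.

Compound 1 `CC1(C)C=C(n2ccccc2=O)c2cc(C(=O)c3ccccc3)ccc2O1`: 6.21
Compound 2 `CC1(C)C=C(n2ccccc2=O)c2cc(OCC(=O)c3ccccc3)ccc2O1`: 4.69
Compound 3 `CC1(C)C=C(n2ccccc2=O)c2cc(OC(=O)Nc3ccc(C(F)(F)F)cc3)ccc2O1`: 4.54

The three compounds share one core and differ only in the group carried on its aromatic ring. All were measured in a functional assay (trachea) with Rattus norvegicus as the target; a lower number here means a less potent compound, a higher number a more potent compound, by a factor of ten per unit of this negative logarithm. Compound 1 stands highest of the three, with compound 2 beyond the scatter lower and compound 3 lower still, so compound 1 is the most potent of the measured set.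

Compound 4 `CC1(C)C=C(n2ccccc2=O)c2cc(-c3ccncc3)ccc2O1` is the untested member. Against compound 1 it shows one change: pyridin-4-yl in place of benzoyl on an aromatic carbon. The carbonyl of the benzoyl group is lost, and the aromatic ring now attaches directly to the core.

Going by the values given here, no measured pair tells what such a change does. The two compounds that carry a linker between core and aromatic ring, compound 2 and compound 3, both fall well short of compound 1, which suggests that the benzoyl arrangement of compound 1 matters. A moderate drop, beyond the scatter but far smaller than the fall to compound 2 or compound 3, is expected from compound 1 to compound 4, a number 0.71 log units lower from compound 1 to compound 4 (beyond the scatter). Compound 4 is therefore estimated at 5.5, within a range from 4.6 to 6.4.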

Compound 4, logarithm of the reciprocal of the active concentration, log(1/C): 6.32
Compound 4: the middle estimate sits 0.82 log units below what was measured; low and high end bracket the measured number.
By their numbers in this assay, from the lowest: compounds 3 and 2 (each within the scatter of the next); then compounds 1 and 4 (each within the scatter of the next).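

In this assay, pyridin-4-yl in place of benzoyl on this aromatic carbon gives a number 0.11 log units higher from compound 1 to compound 4 (within the scatter) and so leaves the read-out unchanged within normal scatter. The carbonyl of the benzoyl group is therefore not required for a number at this level: an aromatic ring attached directly to the core, with one ring nitrogen, does as well in this pair. No evidence here explains why the two groups read alike.

The compounds shown leave open whether a plain phenyl ring attached directly at this carbon would match pyridin-4-yl, and so whether the ring nitrogen plays any part. Also open, on these data alone, is how a group with no aromatic ring, such as an amine or a carboxylic acid, would read at this position.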